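One Amide Substituent Exchanged, Clearance Still To Come

The compounds below may be only part of what the source reports. "The series", "measured", "known", "first", "only" and "open" are said of these compounds alone.

Compound 1 `Cc1ccc2[nH]c(C(=O)N[C@H]3CCN(S(=O)(=O)C4CC4)C[C@@H]3C(=O)NCCN(C)C)cc2c1` gives 7 uL/min in an ADME assay on cells (Hepatocyte, Rattus norvegicus) for metabolic stability; a higher number here means faster removal of the compound, a lower number slower removal. Compound 2 `O=C(N[C@H]1CN(S(=O)(=O)c2ccccc2)C[C@@H]1C(=O)N[C@H]1CCCNC1)c1cc(C2CC2)n[nH]1` returns only the limit < 1 uL/min. Compound 3 `O=C(N[C@H]1CN(S(=O)(=O)c2ccccc2)C[C@@H]1C(=O)N[C@H]1CCCNC1)c1cn(C2CC2)cn1` returns only the limit < 1 uL/min.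

Among the measured compounds shown here, compound 3 thus stands at the limit of < 1 uL/min in this assay, at which 2 of the 3 values shown sit, and the single step between measured compounds, a step that the two limits leave unreadable from compound 2 to compound 3, cannot be read in size. Compound 4 `O=C(N[C@H]1CN(S(=O)(=O)c2ccccc2)C[C@@H]1C(=O)N[C@H]1CCCNC1)c1cc(-c2ccc(Cl)cc2)on1` differs from compound 3 in one place: 5-(4-chlorophenyl)-1,2-oxazol-3-yl in place of 1-cyclopropyl-1H-imidazol-4-yl on a carbonyl carbon. For the measured compounds named here, no measured step speaks to this exchange, so the expectation rests only on the limit at which compound 3 sits, which leaves room for an upward move. Compound 4 is expected to show a step of an at least 3.0-fold higher number from compound 3 to compound 4 (0.47 log units; beyond the scatter) in this assay. Compound 4 is estimated at 3 uL/min, within a range from 1 uL/min to 10 uL/min.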

Compound 4, intrinsic clearance in a liver preparation (reported as CLH), per the amount of preparation that the assay uses: 2.22 uL/min
The estimate for compound 4 lay 1.4-fold (0.13 log units) above the measured number; the range from low to high includes it.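

In this assay, the exchange on a carbonyl carbon whose other neighbour is an amide-type nitrogen moves the number clear of the limit: 5-(4-chlorophenyl)-1,2-oxazol-3-yl gives an at least 2.2-fold higher number from compound 3 to compound 4 (0.34 log units; beyond the scatter), and measured against the pyrazole it gives an at least 2.2-fold higher number from compound 2 to compound 4 (0.34 log units; beyond the scatter). The step between the two cyclopropyl compounds cannot be read. The true size of both readable steps stays unknown, since each starts from a limit of the assay: the limit of < 1 uL/min in this assay, at which 2 of the 4 values shown sit.

From the compounds shown here alone, whether the chlorine contributes to the rise remains open. So does what an amine or a carboxylic acid in its place would give.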